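A few compounds are considered here, and "the series" means these few. Any claim that something is new, unique, unknown or untested is made for them only; others in the source may bear on it.

Three measured compounds share one core and differ only in the group on the aromatic carbon of the fused ring. In an ADME assay on HepG2 cells (Homo sapiens) for cytotoxicity, read by luminescence, CellTiter-Glo and ATP content, with a stated time of 72 h (a lower number here means that less compound is needed, a higher number that more compound is needed for the effect), compound 1 `COc1ccc(Oc2ccc3c(NCCCNCc4cc(F)ccc4OC)ccnc3c2)cc1` gives 7000 nM, compound 2 `COc1ccc(F)cc1CNCCCNc1ccnc2cc(CCC(C)C)ccc12` gives 890 nM, and compound 3 `COc1ccc(F)cc1CNCCCNc1ccnc2cc(-c3ccc(C(C)(C)C)cc3)ccc12` gives 620 nM. Compound 3 has the lowest of the three numbers, but its gap to compound 2 lies within the scatter, so the two cannot be ordered; only compound 1 stands clearly apart, as the step of an 11-fold lower number from compound 1 to compound 3 (1.05 log units; beyond the scatter) shows.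

Compound 4 `COc1ccc(F)cc1CNCCCNc1ccnc2cc(Oc3cccc(N(C)C)c3)ccc12` returns to an aryloxy group of the kind carried by compound 1: 3-(dimethylamino)phenoxy in place of 4-(tert-butyl)phenyl on an aromatic carbon. Among the compounds with values here, the one step that bears on this, an 11-fold lower number from compound 1 to compound 3 (1.05 log units; beyond the scatter), went in the other direction and was large; the step of a 1.4-fold lower number from compound 2 to compound 3 (0.16 log units; within the scatter) adds nothing beyond the scatter. On that basis a higher number is expected for compound 4, though the dimethylamino substitution differs from compound 1 and the full size of that step need not recur. Compound 4 is therefore estimated at 3000 nM, with a range of 1000 nM to 9000 nM, corresponding to the expected step of a 4.8-fold higher number from compound 3 to compound 4 (0.68 log units; beyond the scatter).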

Compound 4, half-maximal effective concentration: 3300 nM
Estimate against measurement, compound 4: 1.1-fold (0.04 log units) below, and the stated range covers the measured number.
By their numbers in this assay, from the lowest: compounds 3 and 2 (each within the scatter of the next); then compound 4; then compound 1.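

In this assay, compound 4 separates from the compounds that have no oxygen at this aromatic carbon, with a 5.3-fold higher number from compound 3 to compound 4 (0.73 log units; beyond the scatter) and a 3.7-fold higher number from compound 2 to compound 4 (0.57 log units; beyond the scatter); both compounds with an aryloxy group, compound 1 and compound 4, now have higher numbers than compound 2 and compound 3. The aryloxy compounds also differ from each other, as a 2.1-fold lower number from compound 1 to compound 4 (0.33 log units; beyond the scatter) shows, so the change from 4-methoxyphenyl to 3-(dimethylamino)phenyl on that oxygen moves the number by a modest step beyond the scatter. No measurement available here accounts for either difference.

From the compounds shown here alone, it remains open whether the oxygen or the ring substituent matters more, which a 3-(dimethylamino)phenyl group bonded directly to the aromatic carbon or an unsubstituted phenoxy group could help separate. Going by these compounds, how a carboxylic acid or a morpholine at this position would read also remains unknown.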